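Hydrazone variation at the shared core: notes toward compound 4

The source may hold more compounds than are shown below. What is called first, only, known or untested is meant among the compounds shown, and "the series" means these compounds.

Compound 1, `CCCCc1nc(/C=N/Nc2nc(N)c3ncn([C@@H]4O[C@H](CO)[C@@H](O)[C@H]4O)c3n2)c(Cl)[nH]1`: in an assay on CHO-K1 cells for displacement of a labelled ligand from adenosine receptor A1 (Homo sapiens), read by scintillation counting, with a stated time of 60 min (a lower number here means a stronger inhibitor, a higher number a weaker inhibitor), compound 1 gives 12 nM.
Compound 2, `CSCC/C=N/Nc1nc(N)c2ncn([C@@H]3O[C@H](CO)[C@@H](O)[C@H]3O)c2n1`: in this assay compound 2 gives > 10000 nM, a limit of the assay and not a number.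
Compound 3, `CN(C)c1ccc(/C=N/Nc2nc(N)c3ncn([C@@H]4O[C@H](CO)[C@@H](O)[C@H]4O)c3n2)cc1`: in this assay compound 3 gives > 10000 nM, likewise a limit of the assay.

Compound 3 thus stands at the limit of > 10000 nM in this assay, at which 2 of the 3 values shown sit, with no number of its own. The steps of an at least 830-fold higher number from compound 1 to compound 3 (2.92 log units; beyond the scatter) and an at least 830-fold higher number from compound 1 to compound 2 (2.92 log units; beyond the scatter) are both large and each ends at that limit, while the step that the two limits leave unreadable from compound 2 to compound 3 cannot be read. Compound 4, `Nc1nc(N/N=C/c2ccc(C(F)(F)F)cc2)nc2c1ncn2[C@@H]1O[C@H](CO)[C@@H](O)[C@H]1O`, carries trifluoromethyl in place of dimethylamino on an aromatic carbon. Among the compounds with values here, no measured step exchanges one group on the phenyl for another, so no step bears directly on this change. Compound 4 is expected to stay weak, with a number no higher from compound 3 to compound 4 (the limit leaves the size open) as the estimated step. The estimate for compound 4 is 10000 nM, within 2000 nM to 50000 nM.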

Compound 4, inhibition constant: 37 nM
Compound 4: the middle estimate sits 270-fold (2.43 log units) above what was measured, and the stated range ends above it.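

On the phenyl ring, trifluoromethyl in place of dimethylamino turns a limit into a measured value in this assay, with an at least 270-fold lower number from compound 3 to compound 4 (2.43 log units; beyond the scatter), so a phenyl on the hydrazone does not by itself give a weak compound. A 2-butyl-5-chloro-1H-imidazol-4-yl group is not needed for a measured value, though a 3.1-fold higher number from compound 1 to compound 4 (0.49 log units; beyond the scatter) remains, and 2-(methylsulfanyl)ethyl falls far behind, with an at least 270-fold lower number from compound 2 to compound 4 (2.43 log units; beyond the scatter). Both large steps start from a limit of the assay and not from a number: the limit of > 10000 nM in this assay, at which 2 of the 4 values shown sit.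

As far as these compounds go, whether a nitrile or a carboxylic acid in the place of trifluoromethyl reads like trifluoromethyl or like dimethylamino stays open.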